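The source may report more compounds than this note shows. Statements on the series, on what has been measured and on what is new or still open speak of the compounds shown alone.

Measured compounds:
Compound 1, `CC1=C(N2CC2)C(=O)C(C(C)C)=C(N2CC2)C1=O`: 5.6
Compound 2, `CC(C)C1=C(N2CC2)C(=O)C=C(N2CC2)C1=O`: 5.68

Of the two compounds measured in a functional assay on L1210 cells (Mus musculus), with a stated time of 12 days (on this read-out higher numbers stand for higher potency (the scale is a negative logarithm) and lower numbers for lower potency), compound 2 holds the highest of the two numbers, but compound 1 lies within the scatter of it, so the two cannot truly be told apart. Compound 3, `CC(C)C1=C(N2CC2)C(=O)C(C(C)C)=C(N2CC2)C1=O`, has not yet been measured. It arises from compound 2 by a single change: isopropyl in place of hydrogen on a double-bonded ring carbon. Within the data shown here, only one measured step bears on this change. Going a number 0.08 log units higher from compound 1 to compound 2 (within the scatter), the loss of a methyl from a double-bonded ring carbon left the read-out unchanged beyond the scatter. Placing an isopropyl on a double-bonded ring carbon is therefore expected to move the read-out little, if at all, and the step of a number 0.08 log units lower from compound 2 to compound 3 (within the scatter) is estimated to stay within the scatter. Compound 3 is expected to give 5.6, with a range from 5.2 to 6.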

Compound 3, logarithm of the reciprocal of the active concentration, log(1/C): 4.77
Compound 3: middle estimate off by 0.83 log units, on the high side; the measured number lies below the stated range.
By their numbers in this assay, from the lowest: compound 3; then compounds 1 and 2 (each within the scatter of the next).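

Among these compounds, at this ring carbon, three ring bonds from the ring atom that bears an isopropyl group, the read-out in this assay is not indifferent to the group present: putting isopropyl in place of hydrogen gives a number 0.91 log units lower from compound 2 to compound 3 (beyond the scatter) and marks the first clear change in this small set. Isopropyl in place of methyl gives a number 0.83 log units lower from compound 1 to compound 3 (beyond the scatter), so the loss appears against both smaller substituents, although hydrogen and methyl themselves could not be told apart. Nothing available explains this drop.

Whether the fall sets in gradually or only at isopropyl stays open, as ethyl and a longer chain such as n-propyl are not among the compounds shown. An amine or a methoxy group at this carbon is likewise absent, and every comparison here has isopropyl on the other ring carbon.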